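The compounds below may be only part of what the source reports. "The series", "measured", "known", "first", "only" and "open" are said of these compounds alone.

Values in a functional assay on CCRF-CEM cells (Homo sapiens) for antiproliferative activity, read by trypan blue exclusion, with a stated time of 72 h; a higher number here means a weaker inhibitor, a lower number a stronger inhibitor:
- Compound 1 `COc1ccc(C(=O)NC(N)=O)cc1NC(=O)C(C)Br`: > 20000 nM (a limit)
- Compound 2 `COc1ccc(C(=O)NC(N)=O)cc1NC(=O)C(C)Cl`: > 20000 nM (a limit)
- Compound 3 `NC(=O)NC(=O)c1ccc(Cl)c(NC(=O)CCl)c1`: 15900 nM

In this assay, among the measured compounds shown here, compound 3 gives 15900 nM, the only true number in the set. The other two entries are limits, not numbers: the limit of > 20000 nM in this assay, at which 2 of the 3 values shown sit.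

Compound 4 `COc1ccc(C(=O)NC(N)=O)cc1NC(=O)CCl` keeps the core of compound 3 and carries methoxy in place of chloro on an aromatic carbon, ortho to a ((chloromethyl)carbonyl)amino group and para to a carbamoylcarbamoyl group: methoxy in place of chloro on an aromatic carbon.

For the measured compounds named here, the only measured step is a step that the two limits leave unreadable from compound 1 to compound 2. It lies on a saturated chain carbon rather than on the aromatic carbon, so it gives no size for this change. Compound 2 also carries the methoxy and stands at > 20000 nM, which is a limit. That reading gives only a weak hint, since compound 2 also differs from compound 4 in its chain.

The estimated step is a 1.1-fold higher number from compound 3 to compound 4 (0.03 log units; within the scatter), and none beyond the scatter is expected. A reading that returns only a limit would also be no surprise. Compound 4 is expected at 17000 nM, with an estimated range of 6000 nM to 35000 nM.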

Compound 4, half-maximal inhibitory concentration: > 20000 nM
Compound 4: a limit, no number; the forecaster's own chance of this, stated with the estimate: 40%; middle value at least 1.1-fold (0.07 log units) from the limit.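

Methoxy in place of chloro on the aromatic carbon, ortho to a ((chloromethyl)carbonyl)amino group and para to a carbamoylcarbamoyl group, gives the first step at this position that can be read in this assay: an at least 1.2-fold higher number from compound 3 to compound 4 (0.09 log units; that floor lies within the scatter). The step has a floor only, so it fixes no size and does not separate this change from no change at all. The steps from compound 1 and compound 2 to compound 4 cannot be read, so the methoxy compounds give no comparison among themselves, and compound 3 remains the only entry with a true number, while the rest sit at a single limit: the limit of > 20000 nM in this assay, at which 3 of the 4 values shown sit.

As far as these compounds go, the size of the change from chloro to methoxy stays open, as a methoxy compound with a number would be needed to fix it. Also open, from the compounds shown here alone, is how this aromatic carbon responds to groups other than chloro and methoxy, such as an amine, a methyl or a carboxylic acid, and whether a longer chain in place of the chloromethyl on the carbonyl carbon would bring compounds off the limit.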